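Adding a Methoxy to a Chromone Core: Cytotoxicity Expectation

A few compounds are considered here, and "the series" means these few. Any claim that something is new, unique, unknown or untested is made for them only; others in the source may bear on it.

Measured compounds:
Compound 1, `CC(=O)Nc1ccc2oc(-c3ccc(C(F)(F)F)cc3)cc(=O)c2c1`: 330000 nM
Compound 2, `COc1ccc(-c2cc(=O)c3cc(N)ccc3o2)cc1`: 241000 nM
Compound 3, `Nc1ccc2oc(-c3ccc(C(F)(F)F)cc3)cc(=O)c2c1`: 273000 nM

In an ADME assay on MT4 cells (Homo sapiens) for cytotoxicity, read by MTT assay, with a stated time of 4 days (on this read-out higher numbers stand for lower toxicity in this test and lower numbers for higher toxicity in this test), compound 3 gives 273000 nM and sits second highest of the three numbers, its nearest neighbour being compound 2 and the furthest compound 1; both gaps lie within the scatter. The two measured steps that arrive at compound 3 are small: a 1.2-fold lower number from compound 1 to compound 3 (0.08 log units; within the scatter) and a 1.1-fold higher number from compound 2 to compound 3 (0.05 log units; within the scatter), so neither change of the acetyl nor of the trifluoromethyl moved the read-out beyond noise.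

Compound 4, `COc1c(-c2ccc(C(F)(F)F)cc2)oc2ccc(N)cc2c1=O`, differs from compound 3 in one place: methoxy in place of hydrogen on an aromatic carbon. Among the compounds with values here, no measured pair shows a change at this position on the shared core, so nothing directly bears on it. Given that the three measured compounds all fall within the scatter of one another, the step is expected to be a 1.0-fold lower number from compound 3 to compound 4 (0.00 log units; within the scatter), with no direction beyond the scatter. Compound 4 is therefore estimated at 270000 nM, within the range 130000 nM to 550000 nM.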

Compound 4, half-maximal cytotoxic concentration: 290000 nM
Estimate against measurement, compound 4: 1.1-fold (0.03 log units) below; low and high end bracket the measured number.
By their numbers in this assay, from the lowest: compounds 2, 3, 4 and 1 (each within the scatter of the next).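

Methoxy on this aromatic carbon, two atoms from the ring oxygen and ortho to a large group, gives the first reading at this position, and in this assay the change is a 1.1-fold higher number from compound 3 to compound 4 (0.03 log units; within the scatter). Within the data shown here, at this position on the shared core, then, replacing hydrogen with methoxy leaves the read-out within the scatter, something the earlier steps at the acetyl and the trifluoromethyl could not show. Nothing available bears on the reason for this result.

Only hydrogen and methoxy are shown at this carbon, so it remains open whether a hydroxyl, an amine or a longer ether chain would also stay within the scatter. As far as these compounds go, it is equally open whether methoxy here would give the same outcome with an acetyl on the ring nitrogen.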